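Methoxy in Place of Bromo on the Hydrazone Aryl Ring

The compounds below may be only part of what the source reports. "The series", "measured", "known", "first", "only" and "open" are said of these compounds alone.

Compound 1 `CCOc1ccc(/C=N/NC(=O)COc2cccc3ccccc23)cc1O`: 100 ug/mL
Compound 2 `O=C(COc1cccc2ccccc12)N/N=C/c1ccc(Br)cc1`: > 100 ug/mL
Compound 3 `C/C(=N\NC(=O)COc1cccc2ccccc12)c1ccc([N+](=O)[O-])cc1`: 100 ug/mL

Of the compounds shown here, three with a shared core have been tested in an ADME assay on HEL cells (Homo sapiens) for cytotoxicity; a lower number here means that less compound is tolerated, a higher number that more compound is tolerated. Compound 1 gives 100 ug/mL and compound 3 gives 100 ug/mL. For compound 2 the reading > 100 ug/mL is a limit of the assay and not a number. This is the limit of > 100 ug/mL in this assay, at which 1 of the 3 values shown sits, so where compound 2 truly stands is known only from one side.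

The next compound, compound 4 `COc1ccc(/C=N/NC(=O)COc2cccc3ccccc23)cc1`, differs from compound 2 in a single place: methoxy in place of bromo on an aromatic carbon.

Among the compounds with values here, no step between two measured compounds of this kind is available to guide the expectation. The expected step is therefore a number no higher from compound 2 to compound 4 (the limit leaves the size open), which is none beyond the scatter, in line with compound 1 and compound 3 sitting where they do. Compound 4 is accordingly estimated at 100 ug/mL, within a range from 50 ug/mL to 200 ug/mL, with a fair chance that this assay again reports only a limit.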

Compound 4, minimum cytotoxic concentration: 20 ug/mL
The estimate for compound 4 lay 5.0-fold (0.70 log units) above the measured number, outside the stated range (below it).
By their numbers in this assay, from the lowest: compound 4; then compounds 1 and 3 (each within the scatter of the next).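

The group at this place on the aromatic ring matters: in this assay, methoxy in place of bromo gives an at least 5.0-fold lower number from compound 2 to compound 4 (0.69 log units; beyond the scatter). Within the data shown here, compound 2 gives > 100 ug/mL, which is a limit of the assay and not a number, so the size of this step is known from one side only: the limit of > 100 ug/mL in this assay, at which 1 of the 4 values shown sits. The earlier compounds offered no single-place step at all, and this pair now shows that replacing one small group on this ring can move the tolerated concentration beyond the scatter.

A single pair cannot tell whether the change follows from gaining methoxy or from losing bromo. From the compounds shown here alone, how an amine, a carboxylic acid or a longer chain such as propoxy would read at this place in this assay remains open.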